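Moving the methoxy group: from compound 3 to compound 4

The source may hold more compounds than are shown below. What is called first, only, known or untested is meant among the compounds shown, and "the series" means these compounds.

Measured compounds:
compound 1, `CCN1C(=O)N(CC)C2C1NC(=S)N2/N=C/C=C/c1ccccc1`: 6530 nM
compound 2, `CCN1C(=O)N(CC)C2C1NC(=S)N2/N=C/C=C/c1ccccc1[N+](=O)[O-]`: limit, > 100000 nM
compound 3, `CCN1C(=O)N(CC)C2C1NC(=S)N2/N=C/C=C/c1ccccc1OC`: 610 nM

In a functional assay on A549 cells (Homo sapiens) for inhibition, read by MTT assay, with a stated time of 72 h (a higher number here means a weaker inhibitor, a lower number a stronger inhibitor), compound 1 gives 6530 nM. Compound 2 reaches only the limit of the assay, > 100000 nM, and that is all its entry tells. Compound 3 gives 610 nM, the lowest of the two numbers that are not limits, with compound 1 nearest. Of the measured steps, an at least 15-fold higher number from compound 1 to compound 2 (1.18 log units; beyond the scatter) and an 11-fold lower number from compound 1 to compound 3 (1.03 log units; beyond the scatter); the direct comparison, an at least 160-fold lower number from compound 2 to compound 3 (2.21 log units; beyond the scatter), rests on the limit of compound 2 (the limit of > 100000 nM in this assay, at which 1 of the 3 values shown sits).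

Compound 4, `CCN1C(=O)N(CC)C2C1NC(=S)N2/N=C/C=C/c1ccc(OC)cc1`, differs from compound 3 in a single place: 4-methoxyphenyl in place of 2-methoxyphenyl on a double-bonded chain carbon bound to a double-bonded chain carbon. Going by the values given here, no measured step moves a substituent from one aromatic carbon to another; the steps seen so far show only that what sits on that ring changes the number strongly, in either direction. A change between two positions of the same methoxy group is expected to be smaller than either of those steps, and a 2.5-fold higher number from compound 3 to compound 4 (0.39 log units; beyond the scatter) is the step estimated here. Compound 4 is expected to give about 1500 nM, in a range from 400 nM to 6000 nM.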

Compound 4, half-maximal inhibitory concentration: 17200 nM
Compound 4: middle estimate off by 11-fold (1.06 log units), on the low side; the whole stated range lies below it.
By their numbers in this assay, from the lowest: compound 3; then compound 1; then compound 4. At a limit, above all of these: compound 2.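

In this assay, the placement of the methoxy group matters as much as its presence: 2-methoxyphenyl and 4-methoxyphenyl have the same atoms, yet the change gives a 28-fold higher number from compound 3 to compound 4 (1.45 log units; beyond the scatter). Methoxy in place of hydrogen therefore does not work in one direction, since the 4-methoxyphenyl compound gives a 2.6-fold higher number from compound 1 to compound 4 (0.42 log units; beyond the scatter), the opposite of the gain seen with 2-methoxyphenyl. Compound 2 stands at a limit of the assay, so an at least 5.8-fold lower number from compound 2 to compound 4 (0.76 log units; beyond the scatter) is only a bound: the limit of > 100000 nM in this assay, at which 1 of the 4 values shown sits.

Going by these compounds, whether the position of a group matters as much for anything other than methoxy remains open, for instance for an amine or a carboxylic acid on the same aromatic ring. The values also give no measure of what lies behind the gap between the two methoxy compounds.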